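Second chloro on the shared core: the other isomer

The compounds below may be only part of what the source reports. "The series", "measured", "known", "first", "only" and "open" are said of these compounds alone.

Measured so far in a functional assay on MOLT-4 cells (Homo sapiens) for cytotoxicity, read by sulforhodamine B assay, with a stated time of 48 h; a lower number here means a stronger inhibitor of growth, a higher number a weaker inhibitor of growth:
- compound 1, `ClCc1cccc(Cn2cnc3ncnc(Cl)c32)c1`: 29500 nM
- compound 2, `ClCc1ccccc1Cn1cnc2ncnc(Cl)c21`: 4260 nM
- compound 3, `ClCc1cccc(Cn2cnc3nc(Cl)nc(Cl)c32)c1`: 2290 nM

Among the compounds with values here, the one counted change in the set is chloro in place of hydrogen on an aromatic carbon, and in this assay it gives a 13-fold lower number from compound 1 to compound 3 (1.11 log units; beyond the scatter). Compound 1 and compound 2 share the same atoms joined differently; the difference between the two cores is not broken down here. Their values show compound 2 with the lower number, a gap beyond the scatter. Compound 2 and compound 3 sit within the scatter of each other, so nothing is said about their order.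

Compound 4, `ClCc1ccccc1Cn1cnc2nc(Cl)nc(Cl)c21`, differs from compound 2 by chloro in place of hydrogen on an aromatic carbon. The place words are identical to those of the change from compound 1 to compound 3, so this is the same change on the other core. That change has been measured only once, where it gave a 13-fold lower number from compound 1 to compound 3 (1.11 log units; beyond the scatter). The same change on the other core is expected to run in the same direction but is estimated somewhat smaller, namely a 5.0-fold lower number from compound 2 to compound 4 (0.70 log units; beyond the scatter). In this assay compound 4 is expected at 850 nM, estimated between 250 nM and 3000 nM.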

Compound 4, concentration for total growth inhibition: 3230 nM
The estimate for compound 4 lay 3.8-fold (0.58 log units) below the measured number, outside the stated range (above it).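

In this assay, chloro in place of hydrogen on the core of compound 2 gives a 1.3-fold lower number from compound 2 to compound 4 (0.12 log units; within the scatter), so no effect of the added chloro can be read on this core. The change therefore does not carry over in size from one core to the other, and the gap between the two steps is larger than the scatter allows: the same change on two cores in this assay, a 13-fold lower number (1.11 log units; beyond the scatter) from compound 1 to compound 3 and a 1.3-fold lower number (0.12 log units; within the scatter) from compound 2 to compound 4, 9.8-fold (0.99 log units) apart, beyond the scatter of two such steps. With one pair on each core, this shows that the size of the step was not transferable between these two pairs, but it does not show why, nor how the change would behave on any further core.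

Still open, from the compounds shown here alone, is whether another group at the same place, between two ring nitrogen atoms, such as an amine or a methoxy group, would also separate the two cores. Also open, going by these compounds, is how the two cores would compare if the chloromethyl group gave way to a hydroxymethyl group or a longer chain.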